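This account rests on a few compounds, and the source may have more. Where it says the series, first, only, none or still open, it means among the compounds named here.

Measured so far in a functional assay on HCC 2998 cells (Homo sapiens) for cytotoxicity, read by sulforhodamine B assay, with a stated time of 48 h; on this read-out higher numbers stand for weaker inhibition of growth and lower numbers for stronger inhibition of growth:
- Compound 2, `ClCc1ccccc1Cn1cnc2c(Cl)ncnc21`: 1660 nM
- Compound 3, `ClCc1ccc(Cn2cnc3c(Cl)nc(Cl)nc32)cc1`: 10200 nM
- Compound 1, `ClCc1ccccc1Cn1cnc2c(Cl)nc(Cl)nc21`: "not determined" (no result reported)

Of the two numbers in hand, compound 2 has the lowest, and the gap to compound 3 lies beyond the usual scatter, so compound 2 is the stronger growth inhibitor of the pair. Compound 4, `Nc1nc(Cl)c2ncn(Cc3ccccc3CCl)c2n1`, has not been measured yet. It differs from compound 2 by a single change: amino in place of hydrogen on an aromatic carbon. For the measured compounds named here, no measured pair shows this change, so its effect is unknown; the expectation is a step in this assay of modest size, if any, in either direction. Compound 4 is estimated at 2500 nM, within 800 nM to 8000 nM, which means an expected step of a 1.5-fold higher number from compound 2 to compound 4 (0.18 log units; within the scatter).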

Compound 4, concentration for 50% growth inhibition: 3020 nM
Estimate against measurement, compound 4: 1.2-fold (0.08 log units) below; the range from low to high includes it.
By their numbers in this assay, from the lowest: compounds 2 and 4 (each within the scatter of the next); then compound 3.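

In this assay, for the compounds shown here, amino in place of hydrogen on the aromatic carbon between two ring nitrogen atoms gives a 1.8-fold higher number from compound 2 to compound 4 (0.26 log units; within the scatter) and so shows that this position can carry amino with no step that stands out from the scatter. At this stage, compound 2 and compound 4 cannot be told apart in growth inhibition. Nothing available explains this result.

Other groups at this carbon, such as methoxy or dimethylamino, remain open. Compound 1, with chloro here, has no reported result, so that change cannot be read.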